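Removing the Methyl from a Methylsulfanyl Quinazoline

This account rests on a few compounds, and the source may have more. Where it says the series, first, only, none or still open, it means among the compounds named here.

Measured compounds:
compound 1 `COc1ccc(CNc2nc([SeH])nc3ccccc23)cc1` — 71600 nM
compound 2 `COc1ccc(CNc2nc(SC)nc3ccccc23)cc1` — 70200 nM

In a functional assay on HT-29 cells (Homo sapiens) for cytotoxicity, read by MTT assay, with a stated time of 72 h (on this read-out lower numbers stand for stronger inhibition of growth and higher numbers for weaker inhibition of growth), compound 2 gives 70200 nM. Within the data shown here, compound 1 gives 71600 nM in this assay, so the two numbers cannot be told apart; the step of a 1.0-fold lower number from compound 1 to compound 2 (0.01 log units; within the scatter) is within the scatter, and compound 2 stands level with the only other compound measured.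

Compound 3 `COc1ccc(CNc2nc(S)nc3ccccc23)cc1` is the next member. The change from compound 2 to compound 3 is hydrogen in place of methyl on a sulfur, so a methylsulfanyl group becomes a sulfanyl group on the shared core. Among the measured compounds shown here, the only measured step that bears on it is a 1.0-fold lower number from compound 1 to compound 2 (0.01 log units; within the scatter), which swapped a selenium-bound hydrogen for a methylsulfanyl group and moved the number hardly at all. A hydrogen on sulfur sits between those two cases, so the expected step of a 1.0-fold higher number from compound 2 to compound 3 (0.00 log units; within the scatter) is none beyond the scatter. Compound 3 is therefore estimated at 71000 nM in this assay, within a range from 35000 nM to 145000 nM.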

Compound 3, concentration for 50% growth inhibition: 6490 nM
Compound 3: middle estimate off by 11-fold (1.04 log units), on the high side; the measured number lies below the stated range.
By their numbers in this assay, from the lowest: compound 3; then compounds 2 and 1 (each within the scatter of the next).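

The sulfur position on the shared core proves sensitive in this assay: the earlier pair had shown no movement there, yet taking away the methyl gives an 11-fold lower number from compound 2 to compound 3 (1.03 log units; beyond the scatter). The sulfanyl compound also parts from its selenium counterpart, with an 11-fold lower number from compound 1 to compound 3 (1.04 log units; beyond the scatter), so a hydrogen on sulfur does not read like a hydrogen on selenium, and the level numbers of compound 1 and compound 2 do not mean that the position is indifferent. Nothing available here gives a reason for either step.

The compounds shown leave open whether the hydrogen on sulfur is what matters most, since they do not tell how an amine, a hydroxyl or a longer chain such as ethylsulfanyl would read at this place. Going by these compounds, whether a step of this size carries over to other cells also stays open.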